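The source may hold more compounds than are shown below. What is called first, only, known or untested is meant among the compounds shown, and "the series" means these compounds.

Measured compounds in a functional assay on Ehrlich cells (Mus musculus) for antiproliferative activity, read by trypan blue exclusion, with a stated time of 2 h, tested at 100 ug/mL; on this read-out lower numbers stand for a weaker effect and higher numbers for a stronger effect at the one concentration tested:
compound 1, `N#CC1=C(N)N(c2ccc(S(N)(=O)=O)cc2)C2=C(C(=O)CCC2)C1c1ccccc1`: 40%
compound 2, `N#CC1=C(N)N(c2ccc(S(N)(=O)=O)cc2)C2=C(C(=O)CCC2)C1/C=C/c1ccccc1`: 45%
compound 3, `COc1cc(CC2C(C#N)=C(N)N(c3ccc(S(N)(=O)=O)cc3)C3=C2C(=O)CCC3)ccc1O`: 100%

Compound 2 stands second highest of the three numbers. Its nearest neighbour is compound 1, a number 5 percentage points higher from compound 1 to compound 2 (within the scatter), and its furthest is compound 3, a number 55 percentage points higher from compound 2 to compound 3 (beyond the scatter).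

Compound 4, `N#CC1=C(N)N(c2ccc(S(N)(=O)=O)cc2)C2=C(C(=O)CCC2)C1c1ccc([N+](=O)[O-])cc1`, has not been measured in this assay. It differs from compound 2 in one place: 4-nitrophenyl in place of 2-phenylethenyl on a saturated ring carbon.

Among the compounds with values here, no measured step carries a 4-nitrophenyl group, so the bearing of the earlier steps is indirect. At the same saturated ring carbon, the exchange of phenyl for 2-phenylethenyl gave a number 5 percentage points higher from compound 1 to compound 2 (within the scatter), within the scatter. Only the 4-hydroxy-3-methoxybenzyl group moved the number far, a number 60 percentage points higher from compound 1 to compound 3 (beyond the scatter) and a number 55 percentage points higher from compound 2 to compound 3 (beyond the scatter). Compound 4 carries neither that group nor any other for which a step exists, so the expectation is a change within the scatter, a number 5 percentage points higher from compound 2 to compound 4 (within the scatter). Compound 4 is therefore estimated to give 50% in this assay, expected between 30% and 75%.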

Compound 4, a percentage reported as activity, at one concentration (the size of the read-out at that concentration, not a potency): 100%
For compound 4 the middle estimate is 50 percentage points below the measured one, outside the stated range (above it).
By their numbers in this assay, from the lowest: compounds 1 and 2 (each within the scatter of the next); then compounds 3 and 4 (each within the scatter of the next).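

In this assay the result shows that this saturated ring carbon tolerates a large step without the 4-hydroxy-3-methoxybenzyl group: a number 60 percentage points higher from compound 1 to compound 4 (beyond the scatter) comes from nitro in place of hydrogen on an aromatic carbon, and 4-nitrophenyl in place of 2-phenylethenyl gives a number 55 percentage points higher from compound 2 to compound 4 (beyond the scatter) on the same carbon. Two quite different groups at this position now read alike, with no change at the digits printed from compound 3 to compound 4 (within the scatter) for 4-nitrophenyl in place of 4-hydroxy-3-methoxybenzyl. No measurement at hand accounts for the effect of the nitro group.

Open, going by these compounds, is whether an amine, a carboxylic acid or a methoxy group in place of the nitro on the phenyl ring would give a similar step. With one concentration and no potency, compound 3 and compound 4 also remain unseparated.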